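From a Nitro Group to Fluorine on the Shared Core

This account rests on a few compounds, and the source may have more. Where it says the series, first, only, none or still open, it means among the compounds named here.

Of the compounds shown here, three built on one shared core have been tested in a toxicity assay on the whole organism with Rattus norvegicus as the target, at a dose of 400 mg/kg by the oral route; a lower number here means a weaker effect, a higher number a stronger effect of the compound at the dose given. Compound 1 `Brc1ccccc1OCC1=NCCO1` gives 40%. Compound 2 `Clc1ccccc1OCC1=NCCO1` gives 80%. Compound 3 `O=[N+]([O-])c1ccccc1OCC1=NCCO1` gives 45%. On these numbers compound 3 stands second highest of the three: it lies within the scatter of compound 1, while the step of a number 35 percentage points lower from compound 2 to compound 3 (beyond the scatter) places it clearly beneath compound 2.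

Compound 4 `Fc1ccccc1OCC1=NCCO1` has not yet been measured. It differs from compound 3 in one place: fluoro in place of nitro on an aromatic carbon.

Among the measured compounds shown here, no measured step involves fluoro. For the measured compounds named here, the steps that bear on this change are those that swap one substituent at this same aromatic carbon: a number 40 percentage points higher from compound 1 to compound 2 (beyond the scatter), a number 5 percentage points higher from compound 1 to compound 3 (within the scatter) and a number 35 percentage points lower from compound 2 to compound 3 (beyond the scatter). Two of these three steps were large, so a single swap at this position can move this assay far. Yet compound 1 and compound 3 sit within the scatter of each other, so not every swap does. Fluoro, like chloro and bromo, is a halogen, but those two gave very different numbers, so the direction for compound 4 cannot be read from them. The step of a number 10 percentage points higher from compound 3 to compound 4 (within the scatter) is therefore expected to be modest, with wide uncertainty. Compound 4 is estimated at 55%, within a range from 30% to 85%.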

Compound 4, a percentage reported as activity, at one dose (the size of the read-out at that dose, not a potency): 20%
Estimate against measurement, compound 4: 35 percentage points above; measured number outside the range, below it.
By their numbers in this assay, from the lowest: compound 4; then compounds 1 and 3 (each within the scatter of the next); then compound 2.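

In this assay fluoro gives the lowest number of the four compounds, with a number 25 percentage points lower from compound 3 to compound 4 (beyond the scatter) together with a number 20 percentage points lower from compound 1 to compound 4 (beyond the scatter) and also a number 60 percentage points lower from compound 2 to compound 4 (beyond the scatter) for swaps at this one aromatic carbon. Three halogens at the same position therefore give three clearly separated numbers, so belonging to the halogens does not by itself set the result in this small set, and the swap between chloro and fluoro is the largest step seen here. Nothing available explains why these swaps differ so much.

The compounds shown cover only fluoro, chloro, bromo and nitro at this position, so it remains open how an amine, a methoxy group or a carboxylic acid on the same carbon would compare, and whether the high number of compound 2 is an isolated peak or part of a wider pattern. Also open, going by these compounds, is whether the same order would hold at a different dose, or with these same groups placed on another carbon of the aromatic ring.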